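Swapping the aryl group on a ring nitrogen

The compounds below may be only part of what the source reports. "The series", "measured", "known", "first", "only" and "open" are said of these compounds alone.

Measured compounds:
Compound 1 `COc1ccc(/C=C\C(=O)O)c(OCc2cn(-c3ccc(NC(C)=O)cc3)nn2)c1CC=C(C)C`: 17400 nM
Compound 2 `COc1ccccc1-n1cc(COc2c(/C=C\C(=O)O)ccc(OC)c2CC=C(C)C)nn1`: "not determined" (no result reported)
Compound 3 `COc1ccc(/C=C\C(=O)O)c(OCc2cn(-c3ccccc3I)nn2)c1CC=C(C)C`: "not determined" (no result reported)

The three measured compounds share one core and differ only in the aryl group carried on the ring nitrogen. In a functional assay on T47D cells (Homo sapiens) for cytotoxicity, read by MTT assay, with a stated time of 24 h (a higher number here means a weaker inhibitor, a lower number a stronger inhibitor), compound 1 gives 17400 nM, a weak result. In this assay compound 2 gives "not determined" (no result reported), and compound 3 gives "not determined" (no result reported), so compound 3 stands without any value of its own, and nothing can be said about how it compares with compound 1.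

Compound 4 `COc1ccc(/C=C\C(=O)O)c(OCc2cn(-c3cccc([N+](=O)[O-])c3)nn2)c1CC=C(C)C` is the next compound in the series. It differs from compound 3 in one place: 3-nitrophenyl in place of 2-iodophenyl on an aromatic nitrogen. Among the compounds with values here, no step between measured compounds exists in this set, so there is no measured basis for saying how large a step this change brings, or in which direction. Within the data shown here, the only anchor is compound 1, whose weak value shows what this core with a substituted phenyl on the ring nitrogen has delivered so far.

Compound 4 is therefore expected to land near that anchor, at about 20000 nM in this assay, with a wide range from 5000 nM to 80000 nM, because compound 1 gives 17400 nM and nothing else is known.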

Compound 4, half-maximal inhibitory concentration: 15400 nM
For compound 4 the middle estimate is 1.3-fold (0.11 log units) above the measured one; low and high end bracket the measured number.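

In this assay, within the data shown here, the aryl group on the ring nitrogen can now be compared for the first time, and the step is a 1.1-fold lower number from compound 1 to compound 4 (0.05 log units; within the scatter). The two compounds cannot be told apart in this assay, even though 3-nitrophenyl and 4-acetamidophenyl differ both in the group on the phenyl ring and in where that group sits. For this one pair, then, the swap does not separate the readings, and both compounds remain weak. No measured evidence here accounts for this result.

From the compounds shown here alone, compound 2 and compound 3 have no number, so steps involving them cannot be read, and the effect of replacing 2-iodophenyl with 3-nitrophenyl remains unknown. Going by these compounds, it also remains open whether a phenyl ring carrying an amine or a carboxylic acid, or a simple alkyl chain in place of the phenyl ring on that nitrogen, would give a result clearly different from that of compound 1 and compound 4.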